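Swapping Chloro for Trifluoromethyl on the Urea End

The source may report more compounds than this note shows. Statements on the series, on what has been measured and on what is new or still open speak of the compounds shown alone.

Compound 2 `O=C(Nc1cccc(-n2cc(-c3ccncc3)c(-c3ccc(Cl)c(O)c3)n2)c1)Nc1ccc(Cl)c(Cl)c1` gives the highest number of the three measured compounds in a functional assay on RPMI-8226 cells (Homo sapiens) for inhibition, read by sulforhodamine B assay, with a stated time of 48 h (a higher number here means a weaker inhibitor of growth, a lower number a stronger inhibitor of growth), at 1030 nM. Its methylated relative compound 1 `COc1cc(-c2nn(-c3cccc(NC(=O)Nc4ccc(Cl)c(Cl)c4)c3)cc2-c2ccncc2)ccc1Cl` gives 388 nM, and compound 3 `COc1cc(-c2nn(-c3cccc(NC(=O)Nc4cccc(C(F)(F)F)c4)c3)cc2-c2ccncc2)ccc1Cl` gives 340 nM; the step of a 2.7-fold higher number from compound 1 to compound 2 (0.42 log units; beyond the scatter) follows the removal of the methyl. The new compound 4 `O=C(Nc1cccc(-n2cc(-c3ccncc3)c(-c3ccc(Cl)c(O)c3)n2)c1)Nc1ccc(Cl)c(C(F)(F)F)c1` differs from compound 2 only at the urea end: trifluoromethyl in place of chloro on an aromatic carbon. Going by the values given here, the one measured step that bears on this swap is a 1.1-fold lower number from compound 1 to compound 3 (0.06 log units; within the scatter), where a 3-(trifluoromethyl)phenyl replaced a 3,4-dichlorophenyl with no effect beyond the scatter. A similar outcome is therefore expected here, a step of a 1.1-fold lower number from compound 2 to compound 4 (0.06 log units; within the scatter). Compound 4 is expected to give about 900 nM, within a range from 400 nM to 2000 nM.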

Compound 4, concentration for 50% growth inhibition: 580 nM
Compound 4: middle estimate off by 1.6-fold (0.19 log units), on the high side, within the range that was stated.
By their numbers in this assay, from the lowest: compounds 3, 1, 4 and 2 (each within the scatter of the next, the first and the last beyond it).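

Here the trifluoromethyl replaces a single chloro while the 4-chloro group stays in place, a cleaner test of this position than the earlier swap, which also removed that chloro. In this assay the result is a 1.8-fold lower number from compound 2 to compound 4 (0.25 log units; within the scatter), so on this compound, with its free hydroxyl, the position accepts either group without a change that can be told from scatter. No measured evidence gives a reason for this outcome.

The compounds shown leave open how a nitrile or an amine would behave at this position. They also leave open whether the same swap would read alike in compound 1 , which keeps the methyl on the oxygen.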